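From 5-(trifluoromethyl)pyridin-2-yl to 4-(tert-butyl)phenyl on sulfur

The source may report more compounds than this note shows. Statements on the series, on what has been measured and on what is new or still open speak of the compounds shown alone.

Of the compounds shown here, two have numbers so far in a functional assay on A-375 cells (Homo sapiens) for inhibition, read by CCK-8 assay, with a stated time of 72 h, tested at 8 uM; a higher number here means more inhibition of growth at the concentration tested, a lower number less inhibition of growth. Compound 1 `CCc1ccc(SCc2ccc(/C=C/C(=O)Nc3ccccc3N)cc2)cc1` gives 58.4%. Going by the values given here, compound 2 `Nc1ccccc1NC(=O)/C=C/c1ccc(CSc2ccc(C(F)(F)F)cn2)cc1` gives 3.96%, the lower of the two and well beyond the scatter from its only neighbour.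

The next change leads to compound 3 `CC(C)(C)c1ccc(SCc2ccc(/C=C/C(=O)Nc3ccccc3N)cc2)cc1`, with 4-(tert-butyl)phenyl in place of 5-(trifluoromethyl)pyridin-2-yl on a sulfur.

Among the compounds with values here, one measured step bears on this: a number 54.4 percentage points lower from compound 1 to compound 2 (beyond the scatter), with 5-(trifluoromethyl)pyridin-2-yl in place of 4-ethylphenyl on the same sulfur. The new change runs the other way, back to a six-membered aromatic ring of carbon only, so compound 1 at 58.4% is the closest guide. A large rise in this assay is therefore expected, of similar size to that drop. Within the data shown here, no measurement yet compares 4-(tert-butyl)phenyl with 4-ethylphenyl, so the range stays wide.

The estimated change is a number 48 percentage points higher from compound 2 to compound 3 (beyond the scatter). For compound 3 the expected value is 52%, with an estimated range of 28% to 75%.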

Compound 3, percent growth inhibition at one concentration: 35.5%
Compound 3: the middle estimate sits 16.5 percentage points above what was measured, and the stated range covers the measured number.
By their numbers in this assay, from the lowest: compound 2; then compound 3; then compound 1.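

In this assay, 4-(tert-butyl)phenyl in place of 5-(trifluoromethyl)pyridin-2-yl on the sulfur gives a number 31.5 percentage points higher from compound 2 to compound 3 (beyond the scatter), so both compounds with a six-membered aromatic ring of carbon only at this place now stand above compound 2. The group on that ring also matters, as tert-butyl in place of ethyl on an aromatic carbon gives a number 22.9 percentage points lower from compound 1 to compound 3 (beyond the scatter), so the carbon-only ring does not by itself set the level of growth inhibition. No measured evidence on hand accounts for either step.

Compound 2 differs from compound 1 and compound 3 in both the ring atoms and the group on the ring, so the shares of the ring nitrogen and the trifluoromethyl group in its low number remain unseparated; 4-(trifluoromethyl)phenyl on the sulfur would address this directly. The trend with the group on the carbon ring rests on ethyl and tert-butyl alone, leaving open how an unsubstituted phenyl, a 4-methylphenyl or a 4-methoxyphenyl would compare.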